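Notes on the amide nitrogen change from compound 1

The source may report more compounds than this note shows. Statements on the series, on what has been measured and on what is new or still open speak of the compounds shown alone.

Measured so far:
compound 1 `COc1cc([C@@H]2C[C@@]2(CO)C(=O)Nc2ccccc2)cc(OC)c1OC`, in a functional assay on HeLa cells (Homo sapiens) for cytotoxicity, read by MTT assay, with a stated time of 48 h (a higher number here means a weaker inhibitor, a lower number a stronger inhibitor), compound 1 gives 86400 nM
compound 2 `CCOC(=O)[C@@]1(C(=O)Nc2ccccc2)C[C@H]1c1cc(OC)c(OC)c(OC)c1`, for which this assay reports only a limit, > 100000 nM
compound 3 `COc1cc([C@H]2C[C@]2(CO)C(=O)Nc2ccccc2)cc(OC)c1OC`, for which this assay reports only a limit, > 100000 nM

Within the data shown here, compound 1 holds the only plain number in the set; the other two values are limits, and the limit of > 100000 nM in this assay, at which 2 of the 3 values shown sit, leaves their true position open. The step of an at least 1.1-fold higher number from compound 1 to compound 2 (0.06 log units; that floor lies within the scatter) and the step of an at least 1.1-fold higher number from compound 1 to compound 3 (0.06 log units; that floor lies within the scatter) both have floors inside the scatter, so neither tells a direction with confidence. Compound 1 and compound 3 are mirror images, as the fact that compounds 1 and 3 differ only in the configuration as drawn records, and both sit at the weak end of the scale.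

Compound 4 `COc1cc([C@@H]2C[C@@]2(CO)C(=O)NCc2ccc(C)cc2)cc(OC)c1OC` differs from compound 1 at the amide nitrogen: 4-methylbenzyl in place of phenyl on an amide-type nitrogen. Among the measured compounds shown here, no measured step touches this nitrogen, so there is no evidence for the size or direction of the step, and the expectation is one within the scatter. Compound 4 is therefore estimated at 90000 nM, with a range from 40000 nM to 200000 nM. That estimate means an expected step of a 1.0-fold higher number from compound 1 to compound 4 (0.02 log units; within the scatter), with a real chance that this assay again reports only a limit.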

Compound 4, half-maximal inhibitory concentration: 41200 nM
Estimate against measurement, compound 4: 2.2-fold (0.34 log units) above; the measured number falls inside the stated range.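

In this assay, among these compounds, the amide nitrogen gives the first step that can be read as a change: a 2.1-fold lower number from compound 1 to compound 4 (0.32 log units; beyond the scatter) and this modest step points toward a lower number. The hydroxymethyl and configuration changes gave no direction, so this nitrogen is the only place in the shown series where a change has a readable direction. The exchange of anilino for (4-methylbenzyl)amino also gives a second plain number, which the earlier limits did not provide.

Going by these compounds, whether the benzyl group without its methyl, or 2-phenylethyl on this nitrogen, would give a similar step remains open. The steps to compound 2 and compound 3 cannot be read, so the roles of hydroxymethyl and of configuration also stay open: the limit of > 100000 nM in this assay, at which 2 of the 4 values shown sit.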